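Moving the methoxy group on the pendant phenyl ring of compound 1

A few compounds are considered here, and "the series" means these few. Any claim that something is new, unique, unknown or untested is made for them only; others in the source may bear on it.

This account concerns a small set of compounds sharing a common core and examined in an assay on HL-60 cells for inhibition of glutathione S-transferase P (Homo sapiens), read by spectrophotometry, tested at 20 uM; a lower number here means less inhibition, a higher number more inhibition at the concentration tested (going by the name of the read-out). Compound 1 `COc1ccccc1/C=C1\CN(CC(=O)O)c2c(C)cccc2C1=O` gives 4.72% in this assay, the lowest of the three measured values. Compound 2 `COc1cc(/C=C2\CN(CC(=O)O)c3ccc(C)cc3C2=O)cc(OC)c1` gives 23.8%, and compound 3 `Cc1cccc(/C=C2\CN(CC(=O)O)c3c(Cl)cccc3C2=O)c1` gives 45.6%; both lie beyond the scatter above compound 1, with compound 2 the nearer and compound 3 the further.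

The unmeasured compound 4 `COc1ccc(/C=C2\CN(CC(=O)O)c3c(C)cccc3C2=O)cc1` differs from compound 1 in a single respect: 4-methoxyphenyl in place of 2-methoxyphenyl on a double-bonded chain carbon bound to a double-bonded ring carbon. The two share every atom; only the attachment point of the methoxy group on the pendant ring moves.

For the measured compounds named here, no measured pair in this set differs in just this way, so the size of the step cannot be read off directly. Given that the two other measured compounds sit above compound 1, a small upward step is expected, likely within or just beyond the scatter: the step from compound 1 to compound 4 is expected to be a number 9.3 percentage points higher from compound 1 to compound 4 (within the scatter). Compound 4 is therefore estimated at 14%, with a range from 0% to 38%.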

Compound 4, a percentage reported as inhibition, at one concentration (the size of the read-out at that concentration, not a potency): 31.5%
For compound 4 the middle estimate is 17.5 percentage points below the measured one; low and high end bracket the measured number.
By their numbers in this assay, from the lowest: compound 1; then compounds 2 and 4 (each within the scatter of the next); then compound 3.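

Moving the methoxy group alone, with every atom kept, gives a number 26.8 percentage points higher from compound 1 to compound 4 (beyond the scatter) in this assay, so the attachment point on the pendant ring matters by itself on this shared core. The earlier compounds shown here could not show this, since they differ from one another in more than one place and so offered no single change to read. No evidence at hand accounts for the step.

The compounds shown leave open how 3-methoxyphenyl would compare at this same place on a double-bonded chain carbon bound to a double-bonded ring carbon, and whether a hydroxyl or an ethoxy group in place of methoxy would follow the same order. They also leave open whether the move from 2-methoxyphenyl to 4-methoxyphenyl would give a similar step on a core carrying chlorine.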